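The source may hold more compounds than are shown below. What is called first, only, known or untested is meant among the compounds shown, and "the series" means these compounds.

In a functional assay on MCF7 cells (Homo sapiens) for cytotoxicity, read by MTT assay, with a stated time of 48 h (a higher number here means a weaker inhibitor, a lower number a stronger inhibitor), compound 1 `CCOc1ccccc1-c1nnc(SCCn2c([N+](=O)[O-])cnc2C)o1` gives 25900 nM and compound 2 `Cc1ncc([N+](=O)[O-])n1CCSc1nnc(-c2ccccc2[N+](=O)[O-])o1` gives 18300 nM while compound 3 `Cc1ncc([N+](=O)[O-])n1CCSc1nnc(-c2ccccc2Cl)o1` gives 22500 nM on the same scale. Compound 3 therefore stands within the scatter of both others: a 1.2-fold lower number from compound 1 to compound 3 (0.06 log units; within the scatter) and a 1.2-fold higher number from compound 2 to compound 3 (0.09 log units; within the scatter) are small, as is a 1.4-fold lower number from compound 1 to compound 2 (0.15 log units; within the scatter) among these ethoxy, nitro and chloro variants. Going by the values given here, the change to compound 4 `Cc1ncc([N+](=O)[O-])n1CCSc1nnc(-c2cccnc2)o1` is pyridin-3-yl in place of 2-chlorophenyl on an aromatic carbon and goes beyond those steps, which only exchanged a substituent; no measured compound has a hetero atom in that ring. They bear on it only indirectly. In this assay no step beyond the scatter is expected. The expected step is a 1.1-fold higher number from compound 3 to compound 4 (0.03 log units; within the scatter) in size. Compound 4 is estimated at 24000 nM with an expected range from 11000 nM to 50000 nM for now.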

Compound 4, half-maximal inhibitory concentration: 28700 nM
For compound 4 the middle estimate is 1.2-fold (0.08 log units) below the measured one, within the range that was stated.
By their numbers in this assay, from the lowest: compounds 2, 3, 1 and 4 (each within the scatter of the next).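

In this assay, pyridin-3-yl in place of 2-chlorophenyl gives a 1.3-fold higher number from compound 3 to compound 4 (0.11 log units; within the scatter). Compound 1, compound 2 and compound 3 all carry a ring of carbon only at this position, whereas compound 4 shows that a ring with a hetero atom and a hydrogen-bond acceptor also leaves the number within the scatter, so exchanging the ring itself, not only its substituent, produces no readable change here. Nothing available explains this result. Still open, from the compounds shown here alone, is whether a non-aromatic group at this position, such as an amine or a carboxylic acid, would give a step beyond the scatter. Going by these compounds, a longer chain in place of the thioethyl link in the shared core is equally open.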